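The source may hold more compounds than are shown below. What is called first, only, known or untested is meant among the compounds shown, and "the series" means these compounds.

Compounds measured so far:
- compound 1, `CCCCCCCCCCSC[C@H](NC(C)=O)C(=O)CCl`: 4700 nM
- compound 2, `CCCCCCCCCCCCCCSC[C@H](NC(C)=O)C(=O)CCl`: 8700 nM
- compound 3, `CCCCCCCCCCCCCCCSC[C@H](NC(C)=O)C(=O)CCl`: 8900 nM

All three share the same core and differ only in how far the saturated chain on the sulfur extends. In a functional assay on NALM-6 cells (Homo sapiens) (on this read-out higher numbers stand for weaker inhibition and lower numbers for stronger inhibition), compound 3 gives 8900 nM, the highest of the three numbers, yet its separation from the others is small: the step of a 1.0-fold higher number from compound 2 to compound 3 (0.01 log units; within the scatter) and the step of a 1.9-fold higher number from compound 1 to compound 3 (0.28 log units; within the scatter) both stay within the scatter, so the three numbers are not really told apart.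

Compound 4, `CCCCCCCCCCCCCCCCCCCCCCSC[C@H](NC(C)=O)C(=O)CCl`, carries the change (heptyl in place of hydrogen on a saturated chain carbon, ten or more bonds along the chain from a sulfur). Going by the values given here, the steps that bear on it are the earlier chain extensions: a 1.9-fold higher number from compound 1 to compound 2 (0.27 log units; within the scatter), a 1.9-fold higher number from compound 1 to compound 3 (0.28 log units; within the scatter) and a 1.0-fold higher number from compound 2 to compound 3 (0.01 log units; within the scatter). None of them went beyond the scatter, and the largest of them added fewer chain carbons than the present change. A still longer chain is therefore expected to give, at most, a modest step toward a higher number, a 1.5-fold higher number from compound 3 to compound 4 (0.16 log units; within the scatter), quite possibly nothing beyond the scatter. Compound 4 is thus estimated at 13000 nM, with a range from 5000 nM to 35000 nM that allows for an unchanged number as well as a clearer weakening.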

Compound 4, half-maximal inhibitory concentration: > 100000 nM
Compound 4: no number, only a limit; the forecaster's own chance of this, stated with the estimate: 25%; middle value at least 7.6-fold (0.88 log units) from the limit.
By their numbers in this assay, from the lowest: compounds 1, 2 and 3 (each within the scatter of the next). At a limit, above all of these: compound 4.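

Lengthening the saturated chain on the sulfur changed nothing beyond the scatter among compounds 1, 2 and 3, but in this assay the heptyl change gives an at least 11-fold higher number from compound 3 to compound 4 (1.05 log units; beyond the scatter), and the octyl change gives an at least 11-fold higher number from compound 2 to compound 4 (1.06 log units; beyond the scatter). In this assay compound 4 gives > 100000 nM, which is a limit of the assay and not a number. This position therefore accepts the chains of compounds 1, 2 and 3 without a clear difference, but not the longer chain of compound 4, and the true size of the loss remains unknown, as the result is a single reading at the limit: the limit of > 100000 nM in this assay, at which 1 of the 4 values shown sits.

The compounds shown leave open where, between the chains of compound 3 and compound 4, the loss of inhibition sets in, and whether it comes on gradually or abruptly; a chain of intermediate length would bear on this. They also leave open whether a long chain carrying an amine or a carboxylic acid would behave like the plain saturated chain of compound 4.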